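From 3-fluorophenyl to 3-bromo-4-fluorophenyl on the amide

The compounds below may be only part of what the source reports. "The series", "measured", "known", "first", "only" and "open" are said of these compounds alone.

In an in vitro ADME assay on microsomes from liver (Mus musculus) for pharmacokinetics, read by LC-MS, with a stated time of 10 min, tested at 1 uM (on this read-out lower numbers stand for slow clearance and higher numbers for fast clearance), compound 1 (`Cc1ccc(NC(=O)[C@H]2CN(C)C[C@@H]2c2ccc(/C=C/C(=O)Nc3ccccc3N)cc2)cc1`) gives 62 mL/min/kg, compound 2 (`CN1C[C@H](C(=O)Nc2ccc(C(F)(F)F)cc2)[C@@H](c2ccc(/C=C/C(=O)Nc3ccccc3N)cc2)C1`) gives 23 mL/min/kg and compound 3 (`CN1C[C@H](C(=O)Nc2cccc(F)c2)[C@@H](c2ccc(/C=C/C(=O)Nc3ccccc3N)cc2)C1`) gives 56 mL/min/kg. Compound 3 therefore sits within the scatter of compound 1, and both lie clearly above compound 2.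

Compound 4 (`CN1C[C@H](C(=O)Nc2ccc(F)c(Br)c2)[C@@H](c2ccc(/C=C/C(=O)Nc3ccccc3N)cc2)C1`) carries 3-bromo-4-fluorophenyl in place of 3-fluorophenyl on an amide-type nitrogen.

Among the measured compounds shown here, no measured step adds bromine, so the evidence is indirect. The three measured steps all change the group on that same nitrogen. They are a 1.1-fold lower number from compound 1 to compound 3 (0.04 log units; within the scatter), a 2.7-fold lower number from compound 1 to compound 2 (0.43 log units; beyond the scatter) and a 2.4-fold higher number from compound 2 to compound 3 (0.39 log units; beyond the scatter). Only compound 2, at 23 mL/min/kg, departs from the other two, so a large change is not expected in this assay. The expectation is a step within the scatter, leaning lower, and the expected step is a 1.5-fold lower number from compound 3 to compound 4 (0.17 log units; within the scatter). The value estimated for compound 4 is 38 mL/min/kg, with an expected range of 18 mL/min/kg to 70 mL/min/kg.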

Compound 4, clearance: 43 mL/min/kg
Estimate against measurement, compound 4: 1.1-fold (0.05 log units) below, within the range that was stated.
By their numbers in this assay, from the lowest: compounds 2, 4, 3 and 1 (each within the scatter of the next, the first and the last beyond it).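

In this assay the change to 3-bromo-4-fluorophenyl on the amide-type nitrogen gives a 1.3-fold lower number from compound 3 to compound 4 (0.11 log units; within the scatter) and a 1.4-fold lower number from compound 1 to compound 4 (0.16 log units; within the scatter) and a 1.9-fold higher number from compound 2 to compound 4 (0.27 log units; within the scatter) with all three steps within the scatter. Among the earlier compounds, compound 2 stood apart from compound 1 and compound 3, whereas compound 4 lies within the scatter of all of them and so belongs clearly to neither side of that gap. No measurement shown accounts for where compound 4 falls.

Since 3-bromo-4-fluorophenyl differs from 3-fluorophenyl both in its bromine and in where its fluorine stands, the share of each in the step stays unresolved. Also open, on these data alone, is how the clearance would respond to an amine or a carboxylic acid on this phenyl ring, or to a longer chain in its place.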